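Adding a Second Chloro Group to Compound 2

The source may report more compounds than this note shows. Statements on the series, on what has been measured and on what is new or still open speak of the compounds shown alone.

Compound 1 `ClCc1ccc(Cn2cnc3c(Cl)ncnc32)cc1` and compound 2 `ClCc1ccccc1Cn1cnc2ncnc(Cl)c21` share the same atoms joined differently; the difference between the two cores is not broken down here. In a functional assay on SN12C cells (Homo sapiens) for cytotoxicity, read by sulforhodamine B assay, with a stated time of 48 h (on this read-out lower numbers stand for stronger inhibition of growth and higher numbers for weaker inhibition of growth), compound 1 gives 1020 nM, while compound 2 gives 2950 nM. Compound 3 `ClCc1ccc(Cn2cnc3c(Cl)nc(Cl)nc32)cc1` carries the change chloro in place of hydrogen on an aromatic carbon relative to compound 1, and in this assay compound 3 gives 7240 nM, a step of a 7.1-fold higher number from compound 1 to compound 3 (0.85 log units; beyond the scatter). Compound 4 `ClCc1ccccc1Cn1cnc2nc(Cl)nc(Cl)c21` is the unmeasured compound, made from compound 2 by chloro in place of hydrogen on an aromatic carbon, the same change at the same kind of place. Among the compounds with values here, the step expected from compound 2 to compound 4 in this assay is a 5.1-fold higher number from compound 2 to compound 4 (0.71 log units; beyond the scatter), resting on the one observed step of a 7.1-fold higher number from compound 1 to compound 3 (0.85 log units; beyond the scatter) and on the starting value of compound 2, 2950 nM. The value of compound 4 is therefore estimated at 15000 nM, with a plausible range from 5000 nM to 45000 nM.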

Compound 4, concentration for 50% growth inhibition: 1170 nM
For compound 4 the middle estimate is 13-fold (1.11 log units) above the measured one; measured number outside the range, below it.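

On the core of compound 2, the chloro group strengthens growth inhibition in this assay (a 2.5-fold lower number from compound 2 to compound 4 (0.40 log units; beyond the scatter)) instead of weakening it. The change therefore does not carry over from one core to the other, and even its direction reverses: the same change on two cores in this assay, a 7.1-fold higher number (0.85 log units; beyond the scatter) from compound 1 to compound 3 and a 2.5-fold lower number (0.40 log units; beyond the scatter) from compound 2 to compound 4, 18-fold (1.25 log units) apart, beyond the scatter of two such steps
With only these two pairs, this shows that a step measured on one core cannot simply be applied to the other, but it does not show why the two cores differ or how the change would behave on any further core.

The compounds shown leave open whether a different group between the two ring nitrogen atoms, such as an amine or a methoxy group, would also behave differently on the two cores. They also leave open whether a bromo or fluoro group there would follow the chloro group.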